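Replacing the 3-methoxybenzyl of compound 3 with butyl

The compounds below may be only part of what the source reports. "The series", "measured", "known", "first", "only" and "open" are said of these compounds alone.

Measured compounds:
compound 1 `CC(C)=CCn1c(CN2CCN(C(=O)C3CC3)CC2)nc2ccccc21`: 74.3%
compound 2 `O=C(C1CC1)N1CCN(Cc2nc3ccccc3n2Cc2ccc(Cl)cc2)CC1`: 56.6%
compound 3 `COc1cccc(Cn2c(CN3CCN(C(=O)C4CC4)CC3)nc3ccccc32)c1`: 44.4%

All three compounds share one core and differ only in the group on a saturated chain carbon bound to an aromatic nitrogen. In an assay on isolated protein for inhibition of aldehyde dehydrogenase 1A1 (Homo sapiens), read by spectrophotometry, tested at 10 uM (on this read-out lower numbers stand for less inhibition and higher numbers for more inhibition at the one concentration tested (going by the name of the read-out)), compound 3 stands lowest of the three: the step of a number 12.2 percentage points lower from compound 2 to compound 3 (beyond the scatter) and the step of a number 29.9 percentage points lower from compound 1 to compound 3 (beyond the scatter) both lie beyond the scatter, so compound 3 gives the lowest inhibition in this assay among those measured.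

Compound 4 `CCCCn1c(CN2CCN(C(=O)C3CC3)CC2)nc2ccccc21` differs from compound 3 in one place: propyl in place of 3-methoxyphenyl on a saturated chain carbon bound to an aromatic nitrogen. Within the data shown here, the steps that bear on this change are the two in which an aromatic ring took the place of the 2-methylprop-1-en-1-yl chain of compound 1, namely a number 17.7 percentage points lower from compound 1 to compound 2 (beyond the scatter) and a number 29.9 percentage points lower from compound 1 to compound 3 (beyond the scatter); both lowered inhibition by a modest amount. Compound 4 goes the opposite way, from a ring back to a chain without a ring, so the expected step in this assay is upward, of modest size, roughly a number 17.6 percentage points higher from compound 3 to compound 4 (beyond the scatter). Among the measured compounds shown here, no measured step involves a plain saturated chain, so the estimate stays wide. Compound 4 is therefore expected to give about 62%, estimated to fall between 45% and 78%.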

Compound 4, a percentage reported as inhibition, at one concentration (the size of the read-out at that concentration, not a potency): 18.2%
Beside the measured number, compound 4's estimate is 43.8 percentage points above it, outside the stated range (below it).
By their numbers in this assay, from the lowest: compound 4; then compound 3; then compound 2; then compound 1.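

In this assay, a group without a ring at this position does not by itself raise inhibition: the propyl of compound 4, on a saturated chain carbon bound to an aromatic nitrogen, gives the lowest number of the four, with steps of a number 26.2 percentage points lower from compound 3 to compound 4 (beyond the scatter) and a number 38.4 percentage points lower from compound 2 to compound 4 (beyond the scatter). The two compounds without a ring in this group now stand at opposite ends of the series, a number 56.1 percentage points lower from compound 1 to compound 4 (beyond the scatter), while compound 2 and compound 3, which carry aromatic rings, lie in the middle, so compound 4 goes against any simple rule that a ring here lowers the number. No measurement is available that explains this order.

The groups of compound 1 and compound 4 differ at once in a branch and a double bond, and the compounds shown do not separate these two features. On these data alone, a 3-methylbutyl group at the same place would keep the branch without the double bond, and how a chain ending in an amine would behave here also stays open.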